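This account rests on a few compounds, and the source may have more. Where it says the series, first, only, none or still open, it means among the compounds named here.

Of the compounds shown here, three from this series have been tested so far in a functional assay on MCF7 cells (Homo sapiens) for inhibition, read by MTT assay; a lower number here means a stronger inhibitor, a higher number a weaker inhibitor. Compound 1 `CCCCCCCCn1cc(/C=C/C(=O)c2ccc(NC(=O)CN3CCN(c4ccccc4)CC3)cc2)nn1` gives 31900 nM in this assay. Compound 2 `CCCCCCCCCCn1cc(/C=C/C(=O)c2ccc(NC(=O)CN3CCN(c4ccccc4)CC3)cc2)nn1` reaches only a limit of this assay, > 100000 nM. Among the measured compounds shown here, the single measured step, an at least 3.1-fold higher number from compound 1 to compound 2 (0.49 log units; beyond the scatter), is therefore known only as a lower bound, since one of the three values sits at the limit of > 100000 nM in this assay, at which 1 of the 3 values shown sits. Compound 3 `O=C(CN1CCN(c2ccccc2F)CC1)Nc1ccc(C(=O)/C=C/c2cn(Cc3ccc(Br)cc3)nn2)cc1` gives 11300 nM in this assay, the lowest of the two numbers shown, with compound 1 nearest to it and separated from it by a gap beyond the scatter.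

Compound 4 `O=C(CN1CCN(c2ccccc2)CC1)Nc1ccc(C(=O)/C=C/c2cn(Cc3ccc(Br)cc3)nn2)cc1` has not yet been measured. It differs from compound 3 in one place: hydrogen in place of fluoro on an aromatic carbon. For the measured compounds named here, none of the measured steps bears on this position; the only step recorded concerns the saturated chain at the aromatic nitrogen, far from the fluorophenyl ring, and it carries no information about removing a fluoro. With nothing to point toward a shift, the expectation for compound 4 is a step of a 1.2-fold higher number from compound 3 to compound 4 (0.09 log units; within the scatter), not beyond the scatter. Compound 4 is therefore estimated to give 14000 nM in this assay, with a range from 5000 nM to 40000 nM.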

Compound 4, half-maximal inhibitory concentration: 49200 nM
Compound 4: the middle estimate sits 3.5-fold (0.55 log units) below what was measured; measured number outside the range, above it.
By their numbers in this assay, from the lowest: compound 3; then compounds 1 and 4 (each within the scatter of the next). At a limit, above all of these: compound 2.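

In this assay, among the compounds shown here, the change from 2-fluorophenyl to phenyl gives the first reading at this position, an aromatic carbon ortho to a large group: a 4.4-fold higher number from compound 3 to compound 4 (0.64 log units; beyond the scatter), whereas the only earlier step concerned the saturated chain on the aromatic nitrogen. With the phenyl kept, the exchange of heptyl for 4-bromophenyl on the saturated chain carbon bound to an aromatic nitrogen gives a 1.5-fold higher number from compound 1 to compound 4 (0.19 log units; within the scatter), so these two groups are not told apart here, and the fluoro marks a larger difference in this short series than that exchange does. The same exchange with nonyl, read against a value that is a limit, gives an at least 2.0-fold lower number from compound 2 to compound 4 (0.30 log units; that floor lies within the scatter), which is only a floor: the limit of > 100000 nM in this assay, at which 1 of the 4 values shown sits.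

On these data alone, whether a chloro, a methyl or a methoxy on the same aromatic carbon would stand with the fluoro or with the hydrogen remains open. As far as these compounds go, the step rests on a single pair carrying the 4-bromophenyl group, so whether it would carry over to the octyl or decyl chains of compound 1 and compound 2 also remains open.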